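A few compounds are considered here, and "the series" means these few. Any claim that something is new, unique, unknown or untested is made for them only; others in the source may bear on it.

Within the data shown here, in a functional assay on RS4-11 cells (Homo sapiens) for inhibition, read by CCK-8 assay, with a stated time of 72 h (a higher number here means a weaker inhibitor, a lower number a stronger inhibitor), two compounds with a shared core have numbers so far. Compound 1 `CC1(C)CCC(CN2CCN(c3ccc(C(=O)NS(=O)(=O)c4ccc(NCC5CCOCC5)c([N+](=O)[O-])c4)c(Oc4cnc5[nH]ccc5c4)c3)CC2)=C(c2ccc(C(F)(F)F)cc2)C1` gives 6.2 nM, and compound 2 `CC1(C)CCC(CN2CCN(c3ccc(C(=O)NS(=O)(=O)c4ccc(NCC5CCOC5)c([N+](=O)[O-])c4)c(Oc4cnc5[nH]ccc5c4)c3)CC2)=C(c2ccc(C(F)(F)F)cc2)C1` gives 24.2 nM, the higher of the two numbers and so the weaker inhibitor of the pair. Compound 3 `CC1(C)CCC(CN2CCN(c3ccc(C(=O)NS(=O)(=O)c4ccc(NC5CCOC5)c([N+](=O)[O-])c4)c(Oc4cnc5[nH]ccc5c4)c3)CC2)=C(c2ccc(C(F)(F)F)cc2)C1` keeps that core and changes the same side chain: oxolan-3-yl in place of (oxolan-3-yl)methyl on a nitrogen on an aromatic ring. In words, oxolan-3-yl stands in place of (oxolan-3-yl)methyl on a nitrogen on an aromatic ring. Among the measured compounds shown here, only one measured step bears on this, and only indirectly: a 3.9-fold higher number from compound 1 to compound 2 (0.59 log units; beyond the scatter), a modest change beyond the scatter, with oxolan-3-yl in place of oxan-4-yl. For the measured compounds named here, no measured pair shows a change of the present kind. Since the substituent also became smaller in that step, a 3.9-fold higher number from compound 1 to compound 2 (0.59 log units; beyond the scatter), a rise in the number is expected here too, though probably a smaller one. The estimated step is a 1.4-fold higher number from compound 2 to compound 3 (0.16 log units; within the scatter), which is expected to stay within the scatter. For compound 3 the estimate is 35 nM, with an expected range of 12 nM to 100 nM.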

Compound 3, half-maximal inhibitory concentration: 32 nM
Compound 3: the middle estimate sits 1.1-fold (0.04 log units) above what was measured; the range from low to high includes it.
By their numbers in this assay, from the lowest: compound 1; then compounds 2 and 3 (each within the scatter of the next).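

In this assay, (oxolan-3-yl)amino in place of ((oxolan-3-yl)methyl)amino gives a 1.3-fold higher number from compound 2 to compound 3 (0.12 log units; within the scatter) and so makes no difference that can be read, which means that, with the five-membered ring kept, this position tolerates the loss of the methyl link. That is new: the earlier step changed the ring and the link together only in part, whereas compound 3 now shows that the two oxolane compounds form one group, and that the ring change from compound 1 remains the larger effect, with a 5.2-fold higher number from compound 1 to compound 3 (0.71 log units; beyond the scatter) as a modest step that goes beyond the scatter. Nothing measured alongside these cell numbers accounts for why compound 1 stands apart from compound 2 and compound 3.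

As far as these compounds go, it remains open how an oxan-4-yl group set directly on the nitrogen would read, and so whether the methyl link is equally dispensable with the six-membered ring. The compounds shown also leave open whether a piperidin-4-yl group or an open 2-methoxyethyl chain on this nitrogen would fall with compound 1 or with compound 3.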